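The source may report more compounds than this note shows. Statements on the series, on what has been measured and on what is new or still open speak of the compounds shown alone.

In an ADME assay on the whole organism (strain CD-1) for pharmacokinetics, with Mus musculus as the target, at a dose of 3 mg/kg by the intravenous route (a higher number here means faster removal of the compound, a lower number slower removal), compound 1 `CN(Cc1ccccc1OCCCCCC(=O)O)C(=O)c1ccc(-c2ccco2)cc1` gives 44 mL/min/kg, compound 2 `CN(Cc1ccccc1OCCCCC(C)(C)C(=O)O)C(=O)c1ccc(-c2ccco2)cc1` gives 1.3 mL/min/kg and compound 3 `CN(Cc1ccccc1OCCC[C@@H]1C[C@@H]1C(=O)O)C(=O)c1ccc(-c2ccco2)cc1` gives 1.7 mL/min/kg. Compound 3 therefore sits level with compound 2, a step of a 1.3-fold higher number from compound 2 to compound 3 (0.12 log units; within the scatter), and far from compound 1. Compound 4 `CN(Cc1ccccc1OCCC/C=C/C(=O)O)C(=O)c1ccc(-c2ccco2)cc1` has 2-carboxyethenyl in place of 2-carboxycyclopropyl (2-carboxyethenyl in place of 2-carboxycyclopropyl on a saturated chain carbon, three bonds along the chain from an oxygen on an aromatic ring). Two large steps bear on this: a 34-fold lower number from compound 1 to compound 2 (1.53 log units; beyond the scatter) and a 26-fold lower number from compound 1 to compound 3 (1.41 log units; beyond the scatter). Each moves away from the open, unbranched chain of compound 1. Compound 4 also lacks the ring, but its double bond means it does not simply repeat that chain, so only a partial return is expected in this assay. The expected step is an 8.2-fold higher number from compound 3 to compound 4 (0.92 log units; beyond the scatter), upward and probably beyond the scatter. Compound 4 is estimated at 14 mL/min/kg, within a range of 4 mL/min/kg to 45 mL/min/kg.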

Compound 4, clearance: 67 mL/min/kg
Estimate against measurement, compound 4: 4.8-fold (0.68 log units) below; measured number outside the range, above it.
By their numbers in this assay, from the lowest: compounds 2 and 3 (each within the scatter of the next); then compounds 1 and 4 (each within the scatter of the next).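

In this assay the change to 2-carboxyethenyl brings a 39-fold higher number from compound 3 to compound 4 (1.60 log units; beyond the scatter) and a 52-fold higher number from compound 2 to compound 4 (1.71 log units; beyond the scatter) so a double bond at this place does not keep the number low as the ring of compound 3 and the methyl branching of compound 2 do. Against the saturated chain there is only a 1.5-fold higher number from compound 1 to compound 4 (0.18 log units; within the scatter) and so, among these four compounds, low numbers go with the ring and the branching, not the double bond. No measurement shown explains this difference. Still open, from the compounds shown here alone, is whether a single methyl branch on the chain would also give a low number. A cyclobutane ring in place of the cyclopropane is equally untested here.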